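Cyano replacing ethoxy: cytotoxicity in mouse macrophage-like cells

The source may report more compounds than this note shows. Statements on the series, on what has been measured and on what is new or still open speak of the compounds shown alone.

Measured compounds:
- compound 1, `O=C(N/N=C/c1ccccc1)c1cnccn1`: 100%
- compound 2, `O=C(N/N=C/c1cccc(F)c1)c1cnccn1`: 49%
- compound 3, `CCOc1cccc(/C=N/NC(=O)c2cnccn2)c1`: 74%

The three compounds share one core and differ only in one group on the benzene ring. In an ADME assay on J774 cells (Mus musculus) for cytotoxicity, read by MTT assay, with a stated time of 48 h, tested at 50 ug/mL (on this read-out higher numbers stand for a weaker effect at the one concentration tested and lower numbers for a stronger effect), compound 1 gives 100%. Compound 3 stands second highest of the three numbers: it lies a number 26 percentage points lower from compound 1 to compound 3 (beyond the scatter) below compound 1 and a number 25 percentage points higher from compound 2 to compound 3 (beyond the scatter) above compound 2, so its effect sits between the two.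

Compound 4, `N#Cc1cccc(/C=N/NC(=O)c2cnccn2)c1`, is the next compound. The change is cyano in place of ethoxy on an aromatic carbon. No measured compound carries a cyano group, so nothing shown tells directly what this group does. What is known is that each group placed on this ring so far has lowered the number relative to hydrogen: a number 51 percentage points lower from compound 1 to compound 2 (beyond the scatter) and a number 26 percentage points lower from compound 1 to compound 3 (beyond the scatter). A third group at the same place might therefore also give a number below that of compound 1, but whether it falls nearer compound 2 or compound 3 cannot be read from these data, so the range must be wide.

Compound 4 is estimated to give 62%, within 35% to 95%. This estimate means an expected step of a number 12 percentage points lower from compound 3 to compound 4 (beyond the scatter), which may well lie within the scatter.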

Compound 4, a percentage reported as activity, at one concentration (the size of the read-out at that concentration, not a potency): 100%
For compound 4 the middle estimate is 38 percentage points below the measured one; measured number outside the range, above it.
By their numbers in this assay, from the lowest: compound 2; then compound 3; then compounds 1 and 4 (each within the scatter of the next).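

In this assay, within the data shown here, the earlier compounds hinted that any group placed on this aromatic carbon, meta to a large group, would give a stronger effect than hydrogen, but the cyano group goes against that hint, with no change at the digits printed from compound 1 to compound 4 (within the scatter). The effect therefore does not come simply from having a group at this place, since the choice of group matters: exchanging ethoxy for cyano gives a number 26 percentage points higher from compound 3 to compound 4 (beyond the scatter), and exchanging fluoro for cyano gives a number 51 percentage points higher from compound 2 to compound 4 (beyond the scatter), so fluoro and ethoxy are the two compounds here that differ from hydrogen. Nothing available explains why cyano parts from fluoro and ethoxy in this way.

The compounds shown leave open how other groups at this place would behave, for example an amine, a carboxylic acid, or a chain longer than ethoxy such as butoxy, and so whether cyano is a lone case or one of many groups that match hydrogen. They also leave open whether fluoro, ethoxy and cyano would keep the same order on the other carbons of this ring.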